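This account rests on a few compounds, and the source may have more. Where it says the series, first, only, none or still open, it means among the compounds named here.

Of the compounds shown here, three that share a core have been measured in an assay on NK92 cells for inhibition of interleukin-15 (Homo sapiens), read by AlphaScreen, with stated times of 30 min and 1 h; a lower number here means a stronger inhibitor, a higher number a weaker inhibitor. Compound 1 `Cn1c(Cc2nn(C)c(=O)c3ccccc23)nnc1SCC(=O)Nc1ccc(Cl)cc1Cl` gives 4500 nM, the highest number of the three and thus the weakest inhibitor in this set. Compound 2 `Cn1c(Cc2nn(C)c(=O)c3ccccc23)nnc1SCCCCCCCC(=O)Nc1ccc(Cl)cc1Cl` gives 190 nM, and compound 3 `Cn1nc(Cc2nnc(SCCCCCCCC(=O)Nc3ccc(Cl)cc3Cl)n2CCC=O)c2ccccc2c1=O` gives 710 nM. Compound 4 `Cn1nc(Cc2nnc(SCC(=O)Nc3ccc(Cl)cc3Cl)n2CCC(=O)O)c2ccccc2c1=O` has not yet been measured; it differs from compound 1 by carboxymethyl in place of hydrogen on a saturated chain carbon bound to an aromatic nitrogen. Among the measured compounds shown here, one measured step touches the same place, namely a 3.7-fold higher number from compound 2 to compound 3 (0.57 log units; beyond the scatter), a modest weakening. A similar change is expected for compound 4 because a 3.7-fold higher number from compound 2 to compound 3 (0.57 log units; beyond the scatter) points that way, so a modest rise in the number is expected, a 2.4-fold higher number from compound 1 to compound 4 (0.39 log units; beyond the scatter). Compound 4 is therefore estimated at 11000 nM, with a likely range from 4000 nM to 30000 nM.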

Compound 4, half-maximal inhibitory concentration: > 30000 nM
Compound 4 gave a limit, no number; the forecaster's own chance of this, stated with the estimate: 15%; middle value at least 2.7-fold (0.43 log units) away from the limit.
By their numbers in this assay, from the lowest: compound 2; then compound 3; then compound 1. At a limit, above all of these: compound 4.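

In this assay compound 4 reaches only a limit, > 30000 nM, and not a number. Carboxymethyl at this place gives an at least 6.6-fold higher number from compound 1 to compound 4 (0.82 log units; beyond the scatter), so this second group at the position also weakens inhibition, as formylmethyl did in a 3.7-fold higher number from compound 2 to compound 3 (0.57 log units; beyond the scatter). The full size of the new step stays unknown: the limit of > 30000 nM in this assay, at which 1 of the 4 values shown sits.

Still open, going by these compounds, is whether carboxymethyl would cost as much on the longer chain of compound 2. Also open, on these data alone, is whether an amine or a methyl ester at this place would be tolerated better.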